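This account rests on a few compounds, and the source may have more. Where it says the series, first, only, none or still open, it means among the compounds named here.

Working notes on the series. Three compounds sharing one core are considered here: compound 1 `NCCCNc1c(C(=O)NCc2ccc(F)cc2)nc(Br)c2cccnc12`, compound 2 `N[C@H]1CC[C@H](Nc2c(C(=O)NCc3ccc(F)cc3)nc(Br)c3cccnc23)CC1` and compound 3 `COC(=O)CNc1c(C(=O)NCc2ccc(F)cc2)nc(Br)c2cccnc12`. In a functional assay on LNCaP cells (Homo sapiens) for cytotoxicity, read by MTT assay, with a stated time of 72 h (on this read-out lower numbers stand for stronger inhibition and higher numbers for weaker inhibition), the entry for compound 1 reads "not determined" (no result reported), so it offers no number for comparison. Compound 2 gives 5000 nM. Going by the values given here, this is the only number available so far, and the one other entry carries no number, so compound 2 has no rank yet.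

The change to compound 3 is (methoxycarbonyl)methyl in place of 4-aminocyclohexyl on a nitrogen on an aromatic ring. Among the compounds with values here, no step between measured compounds is available to size this change. The expectation therefore rests only on compound 2 at 5000 nM and on the structural difference. In this assay a small weakening is expected, not clearly beyond the usual scatter, and the direction remains uncertain. The expected change is a 1.6-fold higher number from compound 2 to compound 3 (0.20 log units; within the scatter). For compound 3 the estimated value is 8000 nM, with an expected range of 2500 nM to 25000 nM.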

Compound 3, half-maximal inhibitory concentration: 5000 nM
The estimate for compound 3 lay 1.6-fold (0.20 log units) above the measured number; low and high end bracket the measured number.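

In this assay, going by these compounds alone, putting (methoxycarbonyl)methyl in place of 4-aminocyclohexyl on a nitrogen on an aromatic ring gives no change at the digits printed from compound 2 to compound 3 (within the scatter), the first step that can be read at this position. The change is not small in structural terms: a six-membered non-aromatic ring with two defined stereocentres and a hydrogen-bond donor leaves, and an open group with no ring, no donor and a double bond outside aromatic rings enters, yet this pair shows no separation in the read-out, so neither that ring nor that donor is needed to keep this level of cytotoxicity in this one comparison. Nothing available explains this result or bears on it.

Steps involving compound 1 cannot be read, so this single pair is all that speaks for the position and no trend can be drawn from it. From the compounds shown here alone, whether a carboxylic acid in place of the methyl ester, a longer chain carrying the ester, or a simple primary amine on a short chain would move the number beyond the scatter remains open.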